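A few compounds are considered here, and "the series" means these few. Any claim that something is new, unique, unknown or untested is made for them only; others in the source may bear on it.

The study turns on three measured amides of a shared core and one still unmeasured. Compound 1 `COc1ccc(CNC(=O)/C=C/c2coc3cc(O)ccc3c2=O)cc1` carries a hydroxy on the core and a methoxy on the aryl group beyond the amide; in a functional assay on Huh-7 cells (Homo sapiens) for inhibition, read by MTT assay, with a stated time of 48 h (a lower number here means a stronger inhibitor, a higher number a weaker inhibitor), compound 1 gives 8430 nM. Compound 2 `O=C(/C=C/c1coc2cc(O)ccc2c1=O)NCc1ccc(F)cc1` differs only beyond the amide. In this assay compound 2 reaches only a limit of the assay, > 100000 nM. The step of an at least 11-fold higher number from compound 1 to compound 2 (1.07 log units; beyond the scatter) is thus a large loss for fluoro in place of methoxy on an aromatic carbon. Compound 3 `COc1ccc2c(=O)c(/C=C/C(=O)NCc3ccc(F)cc3F)coc2c1` carries a methoxy on the core and a difluorinated aryl group beyond the amide. In this assay compound 3 likewise stands only at a limit, > 100000 nM. Compound 3 offers no number, only the limit at which most of the shown values sit, (the limit of > 100000 nM in this assay, at which 2 of the 3 values shown sit).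

Compound 4 `O=C(/C=C/c1coc2cc(O)ccc2c1=O)NCc1ccc(F)cc1F` arises from compound 3 by hydrogen in place of methyl on an oxygen on an aromatic ring: methoxy to hydroxy on the core. Going by the values given here, no measured pair shows this exact change; compound 1 and compound 2 already carry the hydroxy, and the one measured step, an at least 11-fold higher number from compound 1 to compound 2 (1.07 log units; beyond the scatter), concerns the fluorinated group beyond the amide, which compound 4 keeps from compound 3. Compound 2 pairs a hydroxy core with a fluorinated amide substituent and sits at the limit, so the hydroxy cannot be read as restoring a number. Compound 4 is expected to remain near that limit, the step of a number no higher from compound 3 to compound 4 (the limit leaves the size open) being expected to stay small. The estimate for compound 4 in this assay is 100000 nM, in the range from 20000 nM to 300000 nM.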

Compound 4, half-maximal inhibitory concentration: > 100000 nM
Compound 4: only a limit was reported; the forecaster's own chance of this, stated with the estimate: 70%; the middle value lies on the limit itself.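

In this assay compound 4 also stands only at a limit, > 100000 nM, so methoxy to hydroxy on the core of compound 3 brings no number into view, and the steps reaching compound 4 from compound 3 and from compound 2 cannot be read. Going by these compounds alone, the one readable step is an at least 11-fold higher number from compound 1 to compound 4 (1.07 log units; beyond the scatter), a large loss showing that, on the same hydroxy core, the drop seen with the single fluoro also appears with 2,4-difluorophenyl in place of 4-methoxyphenyl. Compound 1 remains the only compound shown with a number, and the others all sit at a limit: the limit of > 100000 nM in this assay, at which 3 of the 4 values shown sit.

The compounds shown leave open whether the number of compound 1 is tied to the methoxy itself, or whether another group at that place on the aryl ring, such as an ethoxy, an amine or a carboxylic acid, would also give a number. They also leave open whether the hydroxy on the core matters when the 4-methoxyphenyl group is kept, and how weak compound 2, compound 3 and compound 4 really are.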